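The source may report more compounds than this note shows. Statements on the series, on what has been measured and on what is new or still open speak of the compounds shown alone.

Measured compounds: compound 1 `O=C(COc1cccc2ccccc12)N/N=C/c1ccc(O)cc1` with 26.5 ug/mL; compound 2 `C/C(=N\NC(=O)COc1cccc2ccccc12)c1ccc([N+](=O)[O-])cc1` with 89.3 ug/mL; compound 3 `C/C(=N\NC(=O)COc1cccc2ccccc12)c1ccc(Br)cc1` with 77.6 ug/mL.

In an ADME assay on MT4 cells (Homo sapiens) for cytotoxicity, read by MTT assay, with a stated time of 4 days (a higher number here means that more compound is tolerated, a lower number that less compound is tolerated), compound 1 gives 26.5 ug/mL, the lowest of the three numbers, with compound 3 and compound 2 both standing beyond the scatter above it. Compound 4 `O=C(COc1cccc2ccccc12)N/N=C/c1cccc(Cl)c1` is not yet measured and differs from compound 1 in one place: 3-chlorophenyl in place of 4-hydroxyphenyl on a carbon with a double bond to nitrogen. Among the measured compounds shown here, the only measured step, a 1.2-fold lower number from compound 2 to compound 3 (0.06 log units; within the scatter), concerns a different pair of compounds and a different change, so it bears on this exchange only loosely; it shows a halogen-bearing ring tolerated as well as its partner. Since compound 3 gives 77.6 ug/mL, a modest rise is expected. Compound 4 is therefore estimated at 50 ug/mL, between 20 ug/mL and 120 ug/mL. The expected step is a 1.9-fold higher number from compound 1 to compound 4 (0.28 log units; within the scatter).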

Compound 4, half-maximal cytotoxic concentration: 89.9 ug/mL
Estimate against measurement, compound 4: 1.8-fold (0.25 log units) below, within the range that was stated.
By their numbers in this assay, from the lowest: compound 1; then compounds 3, 2 and 4 (each within the scatter of the next).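

The exchange of 3-chlorophenyl for 4-hydroxyphenyl on a carbon with a double bond to nitrogen gives a 3.4-fold higher number from compound 1 to compound 4 (0.53 log units; beyond the scatter) in this assay and is the first step among these compounds to lie beyond the scatter. It shows that this position responds to a change of ring substituents on the core of compound 1, where a hydrogen-bond donor and acceptor leave and chlorine enters. Nothing available here bears on why the number moves.

The compounds shown leave open whether losing the hydroxyl or gaining the chlorine carries this step. From the compounds shown here alone, how an amine or a carboxylic acid on the phenyl ring would read also remains open.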